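Phenoxy to Tert-Butyl on the Carbonyl Carbon

The source may report more compounds than this note shows. Statements on the series, on what has been measured and on what is new or still open speak of the compounds shown alone.

Compound 2 `COc1ccc(S(=O)(=O)N2CCc3cccc(NC(=O)Oc4ccccc4)c32)cc1` carries a phenoxy group on a carbonyl carbon. In a functional assay on KB cells (Homo sapiens) for cytotoxicity (a higher number here means a weaker inhibitor, a lower number a stronger inhibitor), compound 2 gives > 10000 nM, which is a limit of the assay rather than a number. Compound 1 `COc1ccc(S(=O)(=O)N2CCc3cccc(NC(=O)N(C)c4ccccc4)c32)cc1` carries methyl(phenyl)amino on that carbonyl carbon instead. In this assay compound 1 gives > 10000 nM, again a limit and not a measured number. The step that the two limits leave unreadable from compound 1 to compound 2 therefore cannot be sized, because the limit of > 10000 nM in this assay, at which 2 of the 2 values shown sit, holds both values.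

Compound 3 `COc1ccc(S(=O)(=O)N2CCc3cccc(NC(=O)C(C)(C)C)c32)cc1` differs from compound 2 by tert-butyl in place of phenoxy on a carbonyl carbon. Among the compounds with values here, no measured step covers this particular change, and the one measured step is unreadable, so nothing points to a shift in either direction beyond the usual scatter. Compound 3 is expected to give 15000 nM in this assay, within a range from 5000 nM to 50000 nM. The step that the limit leaves unreadable from compound 2 to compound 3 implied by this estimate is expected to be essentially none, most likely ending again at a limit.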

Compound 3, half-maximal inhibitory concentration: 359 nM
Compound 3: middle estimate off by 42-fold (1.62 log units), on the high side, and the stated range ends above it.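

Within the data shown here, compound 3 gives the only true number so far in this assay, which shows that the group on this carbonyl carbon can change the read-out, something compounds 1 and 2 could not show. Tert-butyl, which carries no ring, brings an at least 27-fold lower number from compound 2 to compound 3 (1.44 log units; beyond the scatter), and it also brings an at least 27-fold lower number from compound 1 to compound 3 (1.44 log units; beyond the scatter). Both sizes are minimum values, because each step starts from a limit of the assay: the limit of > 10000 nM in this assay, at which 2 of the 3 values shown sit.

These compounds leave open whether the difference follows the loss of the phenyl ring or the loss of the oxygen or nitrogen attached to the carbonyl carbon, as both change together here. As far as these compounds go, how a cyclohexyl group, with a ring of carbon that is not aromatic, or a benzyl group, with its phenyl ring held by carbon, would read at this place remains unknown.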